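This account rests on a few compounds, and the source may have more. Where it says the series, first, only, none or still open, it means among the compounds named here.

Measured in a functional assay on K562 cells (Homo sapiens) for cytotoxicity, read by trypan blue exclusion, with a stated time of 96 h; on this read-out higher numbers stand for weaker inhibition and lower numbers for stronger inhibition:
- compound 1 `COC(=O)[C@H](C)Nc1cc(CS(=O)(=O)/C=C/c2c(OC)cc(OC)cc2OC)ccc1OC`: 200 nM
- compound 2 `COC(=O)C(Nc1cc(CS(=O)(=O)/C=C/c2c(OC)cc(OC)cc2OC)ccc1OC)c1ccc(F)cc1`: 800 nM
- compound 3 `COc1cc(OC)c(/C=C/S(=O)(=O)Cc2ccc(OC)c(NC(C(=O)O)c3ccccc3)c2)c(OC)c1`: 15 nM

Compound 3 stands lowest of the three, and its steps to both others lie beyond the scatter. Compound 4 `COc1cc(OC)c(/C=C/S(=O)(=O)Cc2ccc(OC)c(NC(C(=O)O)c3ccc(Cl)cc3)c2)c(OC)c1` is the next to be read. The structural change is chloro in place of hydrogen on an aromatic carbon, para to a large group.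

Among the measured compounds shown here, no measured step isolates this change. The large 53-fold lower number from compound 2 to compound 3 (1.73 log units; beyond the scatter) comes closest, but it combines carboxy in place of methoxycarbonyl with loss of the fluoro group, so the halogen's share cannot be read from it. The modest 4.0-fold higher number from compound 1 to compound 2 (0.60 log units; beyond the scatter) brings in a whole 4-fluorophenyl ring, not a halogen alone. For the measured compounds named here, both steps leave the one halogenated measured compound with the higher number, which gives weak support for a small rise. The expected change is a 2.3-fold higher number from compound 3 to compound 4 (0.37 log units; beyond the scatter) in this assay, near the edge of the scatter. For compound 4 the estimated value is 35 nM, with an expected range from 12 nM to 120 nM.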

Compound 4, half-maximal inhibitory concentration: 250 nM
Estimate against measurement, compound 4: 7.1-fold (0.85 log units) below, outside the stated range (above it).
By their numbers in this assay, from the lowest: compound 3; then compounds 1 and 4 (each within the scatter of the next); then compound 2.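

In this assay, among the compounds shown here, the step of a 17-fold higher number from compound 3 to compound 4 (1.22 log units; beyond the scatter) is the first to isolate this position, and it shows that chloro in place of hydrogen on this aromatic carbon, para to a large group, is enough to give a large change from a single heavy atom. The step of a 1.3-fold higher number from compound 1 to compound 4 (0.10 log units; within the scatter) leaves those two compounds unseparated, while the step of a 3.2-fold lower number from compound 2 to compound 4 (0.51 log units; beyond the scatter) keeps a modest gap to the fluorinated ester, so the low number of compound 3 does not carry over to its 4-chlorophenyl analogue. No measurement here explains the size of the chloro step.

Open, on these data alone, is whether fluoro, methyl or methoxy on the same aromatic carbon would give a step of similar size. Also open, as far as these compounds go, is how chloro reads at this place with methoxycarbonyl instead of carboxy.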